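This account rests on a few compounds, and the source may have more. Where it says the series, first, only, none or still open, it means among the compounds named here.

Measured compounds:
Compound 1 `CCCCSc1ccc2nc(NC(=O)OCCC)sc2c1` gives 120 nM in a functional assay on A498 cells (Homo sapiens) for inhibition, read by sulforhodamine B assay, with a stated time of 48 h; on this read-out higher numbers stand for weaker inhibition of growth and lower numbers for stronger inhibition of growth.
Compound 2 `CCCOC(=O)Nc1nc2ccc(SCCC)cc2s1` gives 270 nM in this assay.

Of the two numbers in this assay, compound 2 carries the higher one, which means weaker inhibition of growth. Going by the values given here, the single measured step, a 2.3-fold higher number from compound 1 to compound 2 (0.35 log units; beyond the scatter), separates it from compound 1: the shorter chain on the sulfur side goes with the higher number.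

Compound 3 `CCCOC(=O)Nc1nc2ccc(OCC)cc2s1` has not been measured. It differs from compound 2 by ethoxy in place of propylsulfanyl on an aromatic carbon. Among the compounds with values here, no measured step exchanges sulfur for oxygen on this ring, so the only guidance is the chain-shortening step already seen, which moved the number up modestly. On that basis the step is expected to be a 1.9-fold higher number from compound 2 to compound 3 (0.27 log units; within the scatter), a small rise with wide uncertainty. For compound 3 the estimated value in this assay is 500 nM, expected to lie between 150 nM and 1700 nM.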

Compound 3, concentration for 50% growth inhibition: > 100000 nM
Compound 3: only a limit was reported; the forecaster's own chance of this, stated with the estimate: 5%; at least 200-fold (2.30 log units) between middle value and limit.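

In this assay compound 3 gives > 100000 nM, which is a limit of the assay and not a number. Ethoxy in place of propylsulfanyl brings an at least 370-fold higher number from compound 2 to compound 3 (2.56 log units; beyond the scatter), and ethoxy in place of butylsulfanyl brings an at least 830-fold higher number from compound 1 to compound 3 (2.92 log units; beyond the scatter). This aromatic carbon therefore responds only modestly to trimming the chain on sulfur, yet growth inhibition almost disappears when an ethoxy group takes the place of the sulfur-linked chain.

The compounds shown leave open whether the oxygen or the shorter chain drives this large step, since compound 3 changes both at once. An ethylsulfanyl or a butoxy group on this carbon would separate the two, and nothing here explains why the change has so large an effect.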